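A Chloro Group Added to the Phenyl of Compound 3

This account rests on a few compounds, and the source may have more. Where it says the series, first, only, none or still open, it means among the compounds named here.

In a functional assay on OVCAR-3 cells (Homo sapiens) for antiproliferative activity, read by MTT assay, with a stated time of 24 h (on this read-out higher numbers stand for weaker inhibition and lower numbers for stronger inhibition), compound 3 `O=c1[nH]cc(S(=O)(=O)Nc2ccc(-c3cn(-c4ccccc4)nn3)cc2)c(=O)[nH]1` gives 18000 nM, the highest number among the three measured compounds. Compound 1 `Cc1ccccc1-n1cc(-c2ccccc2NS(=O)(=O)c2c[nH]c(=O)[nH]c2=O)nn1` gives 6550 nM, and compound 2 `Cc1cccc(-n2cc(-c3ccccc3NS(=O)(=O)c3c[nH]c(=O)[nH]c3=O)nn2)c1` gives 3150 nM, both lower than compound 3. Within the data shown here, the only measured single-point step is a 2.1-fold lower number from compound 1 to compound 2 (0.32 log units; beyond the scatter), which swaps one methylphenyl for another on an aromatic nitrogen rather than adding a group. Among the measured compounds shown here, compound 4 `O=c1[nH]cc(S(=O)(=O)Nc2ccc(-c3cn(-c4cccc(Cl)c4)nn3)cc2)c(=O)[nH]1` differs from compound 3 by chloro in place of hydrogen on an aromatic carbon; no measured step matches this change, so the guidance is weak. A modest step is therefore expected, and the estimated step from compound 3 to compound 4 is a 1.5-fold lower number from compound 3 to compound 4 (0.18 log units; within the scatter). Compound 4 is expected to give 12000 nM, with a range from 4000 nM to 36000 nM.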

Compound 4, half-maximal inhibitory concentration: 2750 nM
For compound 4 the middle estimate is 4.4-fold (0.64 log units) above the measured one; measured number outside the range, below it.
By their numbers in this assay, from the lowest: compounds 4 and 2 (each within the scatter of the next); then compound 1; then compound 3.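

In this assay, adding one chlorine to turn the phenyl into 3-chlorophenyl gives a 6.5-fold lower number from compound 3 to compound 4 (0.82 log units; beyond the scatter), so stronger inhibition. Unlike the earlier compounds, this pair shows that adding a group at this carbon, meta to a large group, can change the read-out beyond the scatter. No available evidence explains this step. The compounds shown leave open whether this shift is specific to chloro or would also occur with fluoro, methoxy or an amine on the same carbon. They also leave open how chloro would behave on another carbon of this ring.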